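One aromatic group exchanged on compound 2

The source may hold more compounds than are shown below. What is called first, only, known or untested is meant among the compounds shown, and "the series" means these compounds.

compound 1 `CN1CCN(CCCNc2nc3cc([N+](=O)[O-])ccc3nc2NCc2ccc(C(F)(F)F)cc2)CC1` 9.53 ug/mL
compound 2 `CN(C)CCCNc1nc2cc([N+](=O)[O-])ccc2nc1NCc1ccc(Cl)cc1` 10.7 ug/mL

In an ADME assay on HEK293 cells (Homo sapiens) for cytotoxicity, read by MTT assay, with a stated time of 24 h (a lower number here means a stronger inhibitor, a higher number a weaker inhibitor), compound 2 gives 10.7 ug/mL and compound 1 gives 9.53 ug/mL so the two numbers stand within the scatter of each other. Compound 3 `CN(C)CCCNc1nc2cc([N+](=O)[O-])ccc2nc1NCc1ccccc1C(F)(F)F` is still unmeasured and differs from compound 2 by one exchange 2-(trifluoromethyl)phenyl in place of 4-chlorophenyl on a saturated chain carbon bound to a nitrogen on an aromatic ring with 2-(trifluoromethyl)phenyl in place of 4-chlorophenyl on a saturated chain carbon bound to a nitrogen on an aromatic ring. For the measured compounds named here, no measured pair isolates such an exchange, so nothing shows its size directly. Going by the values given here, the only guide is compound 1, which also holds a trifluoromethyl group and gives 9.53 ug/mL even though it differs from compound 2 elsewhere too. No change beyond the scatter is therefore expected, and the estimated move is a 1.1-fold lower number from compound 2 to compound 3 (0.03 log units; within the scatter) in this reading. The estimate for compound 3 is 10 ug/mL with 4.5 ug/mL to 22 ug/mL as the expected span.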

Compound 3, half-maximal inhibitory concentration: 24.7 ug/mL
The estimate for compound 3 lay 2.5-fold (0.39 log units) below the measured number, and the stated range ends below it.
By their numbers in this assay, from the lowest: compounds 1 and 2 (each within the scatter of the next); then compound 3.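

In this assay, 2-(trifluoromethyl)phenyl in place of 4-chlorophenyl on a saturated chain carbon bound to a nitrogen on an aromatic ring gives a 2.3-fold higher number from compound 2 to compound 3 (0.36 log units; beyond the scatter). For the compounds shown here, this modest step is the first direct sign that the number responds to a change at this place, something compound 1 could not show, as it differs from compound 2 in more than one place. No measurement shown here explains the rise.

The exchange alters both the group on the ring and the place named for it, and the compounds shown cannot separate the two. A 2-chlorophenyl group on the core of compound 2 would keep the chlorine and take the 2 position of the new group, so it could show which part of the exchange goes with the higher number.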